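The compounds below may be only part of what the source reports. "The series", "measured", "known", "first", "only" and "open" are said of these compounds alone.

Compound 1 `C/N=C(\S)OC[C@H]1OC(n2cnc3c(NC4CCOC4)ncnc32)[C@H](O)[C@@H]1O`: 45 nM in an assay on DDT1 cells (Cricetulus griseus) for binding affinity to adenosine receptor A1 (Homo sapiens), read by radioligand binding; on this read-out higher numbers stand for weaker inhibition and lower numbers for stronger inhibition
Compound 2 `CCCNC(=O)OC[C@H]1OC(n2cnc3c(NC4CCOC4)ncnc32)[C@H](O)[C@@H]1O`: 235 nM in this assay

Of the two compounds measured in this assay, compound 2 has the higher number, that is the weaker binding, and the step of a 5.2-fold higher number from compound 1 to compound 2 (0.72 log units; beyond the scatter) lies beyond the scatter. Compound 3 `CCC/N=C(\S)OC[C@H]1OC(n2cnc3c(NC4CCOC4)ncnc32)[C@H](O)[C@@H]1O` differs from compound 2 in one place: a group of 6 heavy atoms (4 carbon, 1 nitrogen, 1 sulfur; no ring) in place of a group of 6 heavy atoms (4 carbon, 1 nitrogen, 1 oxygen; no ring), on an oxygen on a saturated carbon. Going by the values given here, the only measured step that bears on this change is a 5.2-fold higher number from compound 1 to compound 2 (0.72 log units; beyond the scatter), and it bears on it only in part, because a 5.2-fold higher number from compound 1 to compound 2 (0.72 log units; beyond the scatter) altered two things at once: the short sulfur-bearing group of compound 1 gave way to a propylcarbamoyl group, so that a longer chain and the exchange of sulfur for oxygen moved together. Compound 3 keeps the propyl chain of compound 2 and restores the sulfur of compound 1. The measured compounds do not separate the share of the chain from the share of the sulfur, so the expected number for compound 3 lies between the two measured ones, leaning toward compound 1. The step from compound 2 is expected to be a 2.6-fold lower number from compound 2 to compound 3 (0.42 log units; beyond the scatter). Compound 3 is therefore estimated at 90 nM, within a range from 30 nM to 270 nM.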

Compound 3, inhibition constant: 50 nM
For compound 3 the middle estimate is 1.8-fold (0.26 log units) above the measured one; the measured number falls inside the stated range.
By their numbers in this assay, from the lowest: compounds 1 and 3 (each within the scatter of the next); then compound 2.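

In this assay, with the propyl chain held the same, putting the sulfur-bearing group in place of propylcarbamoyl gives a 4.7-fold lower number from compound 2 to compound 3 (0.67 log units; beyond the scatter), so on this oxygen on a saturated carbon, the exchange of oxygen for sulfur can now be read on its own, and the sulfur form binds more strongly. Lengthening the chain, with ethyl in place of hydrogen on a saturated chain carbon bound to a double-bonded nitrogen, gives a 1.1-fold higher number from compound 1 to compound 3 (0.05 log units; within the scatter), so this assay detects no effect of that added length. Read together, these two steps place the earlier difference, a 5.2-fold higher number from compound 1 to compound 2 (0.72 log units; beyond the scatter), with the exchange of oxygen for sulfur rather than with the chain, a question that step alone could not settle.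

The data shown offer no measurement that explains why this exchange changes the binding. Also open is whether the flat result for chain length would hold for a longer chain such as hexyl or for a ring such as cyclopentyl on the same nitrogen, since the sulfur-bearing compounds shown carry only methyl and propyl there.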